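The source may report more compounds than this note shows. Statements on the series, on what has been measured and on what is new or still open speak of the compounds shown alone.

Measured so far: compound 1, `O=C(NCc1cc(Cl)ccc1-n1cnnn1)[C@@H]1[C@H]2C[C@H]2CN1C(=O)[C@H](O)CC1CC1`, and compound 2, `COC(C)(C)[C@@H](O)C(=O)N1N=CC[C@H]1C(=O)NCc1cc(Cl)ccc1-n1cnnn1`.

In an ADME assay on Caco-2 cells (Homo sapiens) for permeability, read by LC-MS, in the apical to basolateral direction, with a stated time of 60 min, at pH 6.5 (a higher number here means that the compound crosses the layer faster, a lower number that the compound crosses the layer more slowly), compound 1 gives 3.4 10^-6 cm/s. In this assay compound 2 gives 1.7 10^-6 cm/s. The two numbers lie within the usual scatter of each other, so compound 2 stands together with compound 1, and no order between them can be read from these two values alone.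

Compound 3, `O=C(NCc1cc(Cl)ccc1-n1cnnn1)[C@@H]1CC=NN1C(=O)[C@H](O)C1CCCCC1`, is not yet measured. It differs from compound 2 in one place: cyclohexyl in place of 1-methoxy-1-methylethyl on a saturated chain carbon bound to a carbonyl carbon and an oxygen on a saturated carbon. For the measured compounds named here, no pair of measured compounds shares this change, so there is no measured step to lean on; what is expected rests only on the two values shown.

For compound 3 a modest rise beyond the scatter in this assay is expected, the step of a 2.4-fold higher number from compound 2 to compound 3 (0.37 log units; beyond the scatter) being the estimate. Compound 3 is therefore expected to give about 4 10^-6 cm/s, with a range from 1.6 10^-6 cm/s to 10 10^-6 cm/s.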

Compound 3, apparent permeability: 19 10^-6 cm/s
The estimate for compound 3 lay 4.8-fold (0.68 log units) below the measured number; the measured number lies above the stated range.
By their numbers in this assay, from the lowest: compounds 2 and 1 (each within the scatter of the next); then compound 3.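

At the saturated chain carbon bound to a carbonyl carbon and an oxygen on a saturated carbon, the group proves able to move the number in this assay by a large margin: cyclohexyl in place of 1-methoxy-1-methylethyl gives an 11-fold higher number from compound 2 to compound 3 (1.05 log units; beyond the scatter). For the compounds shown here, this is the first measured change in one place, since compound 1 and compound 2 offered no such step. The counted difference is an open-chain group carrying one hydrogen-bond acceptor replaced by a carbon-only six-membered ring carrying none, but nothing measured here says what lies behind the step.

A single step cannot separate the arrival of the ring from the loss of the methoxy oxygen, so tert-butyl or a tetrahydropyranyl ring at this place would be the informative neighbours. As far as these compounds go, whether the same change carries over to the core of compound 1 remains open.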